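The source may report more compounds than this note shows. Statements on the series, on what has been measured and on what is new or still open speak of the compounds shown alone.

Compound 1 `Fc1ccc(Cn2cnc3c(Cl)ncnc32)cc1` and compound 2 `Nc1ncnc2c1ncn2Cc1ccc(F)cc1` share one core. In an assay on isolated protein for inhibition of Rho-associated protein kinase 1 (Homo sapiens), tested at 30 uM (on this read-out higher numbers stand for more inhibition at the one concentration tested (going by the name of the read-out) and lower numbers for less inhibition), compound 1 gives 0%, and compound 2 gives 0%; the step of no change at the digits printed from compound 1 to compound 2 (within the scatter) stays within the scatter, so compound 2 stands level with compound 1. Compound 3 `Fc1ccc(Cn2cnc3c(Sc4ccccc4)ncnc32)cc1` differs from compound 2 in that (phenylsulfanyl in place of amino on an aromatic carbon). Going by the values given here, the only measured step, amino in place of chloro, showed no change; no measured step has tested a phenylsulfanyl group, so the present swap is an open question. Compound 3 is therefore expected to show a step of a number 5 percentage points higher from compound 2 to compound 3 (within the scatter) no larger than the scatter. Compound 3 is estimated at 5%, ranging from 0% to 30%.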

Compound 3, a percentage reported as inhibition, at one concentration (the size of the read-out at that concentration, not a potency): 2%
Compound 3: the middle estimate sits 3 percentage points above what was measured; the measured number falls inside the stated range.
By their numbers in this assay, from the lowest: compounds 1, 2 and 3 (each within the scatter of the next).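

In this assay, phenylsulfanyl at this aromatic carbon gives a number 2 percentage points higher from compound 2 to compound 3 (within the scatter) in place of amino and a number 2 percentage points higher from compound 1 to compound 3 (within the scatter) in place of chloro. Thus a six-membered aromatic ring of carbon only, brought in through sulfur at this position, leaves the read-out within the scatter, as the swap of chloro for amino did. Nothing available explains this flat result. From the compounds shown here alone, whether a secondary amine, a carboxylic acid or a longer alkyl chain on this carbon would register inhibition stays open, as does the effect of any change elsewhere on the shared core.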